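The compounds below may be only part of what the source reports. "The series", "measured", "known", "first", "only" and "open" are said of these compounds alone.

Working notes on the azo series and its sulfonamide and urea relatives.

Three compounds of the shared core have numbers in an assay on cells for inhibition of Amine oxidase [flavin-containing] B (Homo sapiens), read by Amplex Red, with a stated time of 30 min (on this read-out lower numbers stand for stronger inhibition and higher numbers for weaker inhibition), so far. Compound 1 `O=C1COC(c2ccc(NS(=O)(=O)c3cccc(Cl)c3)cc2)=NN1` carries a sulfonamide link; in this assay compound 1 reaches only the limit > 10000 nM, a limit and not a number (the limit of > 10000 nM in this assay, at which 1 of the 3 values shown sits). Compound 2 `O=C1COC(c2ccc(NC(=O)Nc3cccc(Cl)c3)cc2)=NN1` carries a urea link and in this assay compound 2 gives 2890 nM. Compound 3 `O=C1COC(c2ccc(/N=N/c3cccc(Cl)c3)cc2)=NN1` carries an azo link and in this assay compound 3 gives 287 nM, the lowest of the two numbers, the gap to compound 2 lying beyond the scatter.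

Compound 4 `O=C1COC(c2ccc(/N=N/c3ccc(Cl)cc3)cc2)=NN1` is the next member, not yet measured. It differs from compound 3 in one place: 4-chlorophenyl in place of 3-chlorophenyl on a double-bonded nitrogen. Among the measured compounds shown here, no pair among the measured compounds shows what moving the chlorine within the ring does, so the expectation rests on compound 3 alone. For compound 4 the step from compound 3 is expected to be small, a 1.6-fold higher number from compound 3 to compound 4 (0.20 log units; within the scatter), likely within or just beyond the scatter and, if anything, toward a weaker number. Compound 4 is therefore estimated at 450 nM in this assay, with a range from 120 nM to 1800 nM.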

Compound 4, half-maximal inhibitory concentration: 392 nM
For compound 4 the middle estimate is 1.1-fold (0.06 log units) above the measured one; measured number inside the range.
By their numbers in this assay, from the lowest: compounds 3 and 4 (each within the scatter of the next); then compound 2. At a limit, above all of these: compound 1.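

With 4-chlorophenyl in place of 3-chlorophenyl on a double-bonded nitrogen, this assay shows a 1.4-fold higher number from compound 3 to compound 4 (0.14 log units; within the scatter) and gives the series its first reading of where the chlorine sits on this ring. The two chlorophenyl groups cannot be told apart on this read-out, so for the azo link this pair gives no preference between them. This holds for this one pair only, and no measurement shown bears on why the two groups read alike.

Going by these compounds, whether a nitrile, a methoxy group or an amine in place of the chlorine on this ring would stay in the same range remains open. On these data alone, it also remains open whether the same exchange of chlorophenyl groups would read alike on the urea link of compound 2 or the sulfonamide link of compound 1.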